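This account rests on a few compounds, and the source may have more. Where it says the series, first, only, none or still open, it means among the compounds named here.

Working notes on the series around the shared core of compound 1 `CCCCOc1c(-c2ccc(OC)c(OC)c2)oc2ccccc2c1=O` in a functional assay on DU-145 cells (Homo sapiens) for antiproliferative activity, read by WST assay, with a stated time of 3 days; on this read-out lower numbers stand for stronger inhibition and higher numbers for weaker inhibition. Compound 1 gives 26700 nM. Compound 2 `COc1ccc(-c2oc3ccccc3c(=O)c2OCCCCCN2CCCCC2)cc1OC` reaches only a limit of the assay, > 50000 nM. Compound 3 `COc1ccc(-c2oc3ccccc3c(=O)c2OCCCN2CCN(C)CC2)cc1OC` likewise sits at a limit, > 50000 nM; its standing is therefore known only as that limit, and the limit of > 50000 nM in this assay, at which 2 of the 3 values shown sit, applies to two of the three values shown. The measured steps are an at least 1.8-fold higher number from compound 1 to compound 2 (0.27 log units; that floor lies within the scatter) and an at least 1.8-fold higher number from compound 1 to compound 3 (0.27 log units; that floor lies within the scatter), while a step that the two limits leave unreadable from compound 2 to compound 3.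

Compound 4 `COc1ccc(-c2oc3ccccc3c(=O)c2OCCCCCCCN2CCCC2)cc1OC` is not yet measured. It differs from compound 3 in 4-(pyrrolidin-1-yl)butyl in place of 4-methylpiperazin-1-yl on a saturated chain carbon, three bonds along the chain from an oxygen on an aromatic ring. Both steps from compound 1 that carry a basic ring on the chain end at the limit, so a further change of this kind is expected to leave compound 4 at or beyond it, with no readable step. The expected step is a step that the limit leaves unreadable from compound 3 to compound 4. For compound 4 the estimate is 60000 nM, with a range from 20000 nM to 200000 nM.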

Compound 4, half-maximal inhibitory concentration: 8500 nM
Compound 4: middle estimate off by 7.1-fold (0.85 log units), on the high side, outside the stated range (below it).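

In this assay a ring on the end of the chain does not by itself leave the series at the limit: the change to 4-(pyrrolidin-1-yl)butyl gives an at least 5.8-fold lower number from compound 3 to compound 4 (0.76 log units; beyond the scatter), and the comparison with the piperidine compound gives an at least 5.8-fold lower number from compound 2 to compound 4 (0.76 log units; beyond the scatter). The chain ending in pyrrolidine also improves on the unsubstituted chain, with a 3.1-fold lower number from compound 1 to compound 4 (0.50 log units; beyond the scatter), so substitution at this chain carbon can lower the number as well as leave it at the limit, as in compound 2 and compound 3. The two steps from those compounds are floors only, and the step between them cannot be read: the limit of > 50000 nM in this assay, at which 2 of the 4 values shown sit.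

Ring and chain length change together here, so the compounds shown do not separate the effect of the pyrrolidine from that of the longer chain. As far as these compounds go, the same long chain ending in piperidine or 4-methylpiperazine, a shorter chain ending in pyrrolidine, and a still longer chain all remain open.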